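The source may report more compounds than this note shows. Statements on the series, on what has been measured and on what is new or still open speak of the compounds shown alone.

Measured so far in an assay on isolated protein for displacement of a labelled ligand from metabotropic glutamate receptor 5 (Homo sapiens), with a stated time of 60 min, tested at 1 uM; on this read-out lower numbers stand for less inhibition and higher numbers for more inhibition at the one concentration tested (going by the name of the read-out):
- compound 1 `CC1CCN(c2c(S(=O)(=O)c3cccc(F)c3)cnc3ccc(Cl)cc23)CC1`: 58%
- compound 2 `Cc1cc(C)cc(S(=O)(=O)c2cnc3ccc(C)cc3c2N2CCC(C)CC2)c1`: 80%
- compound 3 `Cc1ccc2ncc(S(=O)(=O)c3ccc(Cl)c(Cl)c3)c(N3CCC(C)CC3)c2c1`: 82%

Compound 3 gives the highest of the three numbers; compound 2 lies within the scatter of it, while compound 1 lies beyond the scatter below it. Compound 4 `Cc1ccc2ncc(S(=O)(=O)c3cccc(F)c3)c(N3CCC(C)CC3)c2c1` differs from compound 3 by 3-fluorophenyl in place of 3,4-dichlorophenyl on a sulfonyl sulfur. Going by the values given here, one measured step touches the sulfonyl aryl group: a number 2 percentage points higher from compound 2 to compound 3 (within the scatter), which shows the change from 3,5-dimethylphenyl to 3,4-dichlorophenyl leaving this assay unmoved. Compound 1 also carries 3-fluorophenyl on the sulfonyl sulfur but has a different core, so its lower number is only suggestive. A modest downward step is therefore expected, a number 14 percentage points lower from compound 3 to compound 4 (beyond the scatter). Compound 4 is estimated at 68%, between 50% and 84%.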

Compound 4, a percentage reported as inhibition, at one concentration (the size of the read-out at that concentration, not a potency): 94%
Beside the measured number, compound 4's estimate is 26 percentage points below it; measured number outside the range, above it.
By their numbers in this assay, from the lowest: compound 1; then compounds 2 and 3 (each within the scatter of the next); then compound 4.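

In this assay the group on the sulfonyl sulfur does move the number: 3-fluorophenyl gives a number 12 percentage points higher from compound 3 to compound 4 (beyond the scatter) and a number 14 percentage points higher from compound 2 to compound 4 (beyond the scatter), whereas the earlier change of aryl group stayed within the scatter. The other position also counts, with methyl in place of chloro on an aromatic carbon giving a number 36 percentage points higher from compound 1 to compound 4 (beyond the scatter) while 3-fluorophenyl stays in place. Nothing available explains either step.

Open, on these data alone, is whether the higher number goes with fluorine itself or with a phenyl carrying a single substituent. Also open, as far as these compounds go, is how an unsubstituted phenyl, or a phenyl carrying an amine or a carboxylic acid, would read on the sulfonyl sulfur.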